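The compounds below may be only part of what the source reports. "The series", "measured", "known", "first", "only" and "open" are said of these compounds alone.

Measured so far in a functional assay on SK-HEP1 cells (Homo sapiens) for inhibition, read by sulforhodamine B assay, with a stated time of 48 h (a lower number here means a stronger inhibitor, a higher number a weaker inhibitor), for the series:
compound 1 `O=C(CCCC(=O)Nc1ccc(NC(=O)Nc2ccc(Cl)c(C(F)(F)F)c2)cc1)NO` gives > 10000 nM (a limit)
compound 2 `O=C(Nc1ccc2c(c1)CCCN2Cc1ccc(C(=O)NO)cc1)Nc1ccc(Cl)c(C(F)(F)F)c1` gives 4500 nM (a number)

The result for compound 1 is a limit of the assay and not a number. Within the data shown here, compound 2 gives 4500 nM in this assay and this is the only true number so far.

Next is compound 3 `O=C(Nc1ccc2c(c1)CCCN2c1ccc(C(=O)NO)cc1)Nc1ccc(Cl)c(C(F)(F)F)c1`, with 4-(hydroxycarbamoyl)phenyl in place of 4-(hydroxycarbamoyl)benzyl on a nitrogen on an aromatic ring in a ring. The counted difference reads 4-(hydroxycarbamoyl)phenyl in place of 4-(hydroxycarbamoyl)benzyl on a nitrogen on an aromatic ring in a ring and nothing else in the structure changes.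

Among the measured compounds shown here, no measured step covers this exchange, so the expectation has little to rest on. In this assay no change beyond the scatter is expected, and the estimated step is a 1.1-fold higher number from compound 2 to compound 3 (0.05 log units; within the scatter) with no firm direction. That expectation starts from compound 2 at 4500 nM as the only numerical anchor. For compound 3 the estimated value is 5000 nM with an expected range of 1500 nM to 15000 nM in this measurement.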

Compound 3, half-maximal inhibitory concentration: 3400 nM
For compound 3 the middle estimate is 1.5-fold (0.17 log units) above the measured one, and the stated range covers the measured number.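

Among these compounds, on a nitrogen on an aromatic ring in a ring, 4-(hydroxycarbamoyl)phenyl in place of 4-(hydroxycarbamoyl)benzyl gives the first step that can be read in this assay: a 1.3-fold lower number from compound 2 to compound 3 (0.12 log units; within the scatter). This position therefore accepts either group without a difference that can be told from repeated measurements, and both groups keep the same six-membered aromatic ring of carbon only and the same counts of hydrogen-bond donors and acceptors. Among the compounds shown here, the single step gives no ground for ascribing a cause to this result, and nothing measured here bears on one.

The two compounds compared here say nothing on whether this nitrogen needs an aromatic group at all, and a plain methyl group there, or a longer chain carrying the hydroxycarbamoyl group, would test that. Also open, as far as these compounds go, is whether a carboxylic acid in place of the hydroxycarbamoyl group, or an amine on the aromatic ring of the entering group, would give a step beyond the scatter in this assay.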